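The source may report more compounds than this note shows. Statements on the series, on what has been measured and on what is new or still open speak of the compounds shown alone.

Compound 2, `N=C(N)NCCC[C@H](NC(=O)CN(c1ncnc2c1ncn2C1CCCCO1)C1CC1)C(=O)OCc1ccccc1`, was tested in a functional assay on the whole organism (Tail, strain ICR) with Mus musculus as the target, in the tail flick test, with a stated time of 150 min, at a dose of 25 umol/kg by the oral route (on this read-out lower numbers stand for a weaker effect and higher numbers for a stronger effect at the one dose given), where compound 2 gives 19.6%. Compound 1, `O=C(CN(c1ncnc2c1ncn2C1CCCCO1)C1CC1)N[C@@H](CO)C(=O)OCc1ccccc1`, gives 18.3% in this assay, and a number 1.3 percentage points higher from compound 1 to compound 2 (within the scatter), so the two numbers lie within the scatter of each other. Compound 3, `CC(C)[C@H](NC(=O)CN(c1ncnc2c1ncn2C1CCCCO1)C1CC1)C(=O)OCc1ccccc1`, differs from compound 2 by a group of 3 heavy atoms (3 carbon; no ring) in place of a group of 7 heavy atoms (4 carbon, 3 nitrogen; no ring), on a saturated chain carbon bound to an amide-type nitrogen and a carbonyl carbon. Going by the values given here, the only measured step that bears on this, from compound 1 to compound 2, also exchanged the group on that chain carbon and gave a number 1.3 percentage points higher from compound 1 to compound 2 (within the scatter). Compound 3 is therefore expected to show no step beyond the scatter, with a number 0.6 percentage points lower from compound 2 to compound 3 (within the scatter). The estimate for compound 3 is 19%, in the range 8% to 30%.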

Compound 3, a percentage reported as activity, at one dose (the size of the read-out at that dose, not a potency): 21.1%
Compound 3: the middle estimate sits 2.1 percentage points below what was measured; the measured number falls inside the stated range.
By their numbers in this assay, from the lowest: compounds 1, 2 and 3 (each within the scatter of the next).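

At the saturated chain carbon bound to an amide-type nitrogen and a carbonyl carbon, isopropyl gives a number 1.5 percentage points higher from compound 2 to compound 3 (within the scatter) and a number 2.8 percentage points higher from compound 1 to compound 3 (within the scatter) in this assay. All three groups at this place therefore give numbers within the scatter of one another, although isopropyl has no hydrogen-bond donors or acceptors and the group it replaces in compound 2 has both. Nothing available explains this result.

From the compounds shown here alone, whether a carboxylic acid, an amine or a longer chain at this carbon would produce a step beyond the scatter remains open.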